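The compounds below may be only part of what the source reports. "The series", "measured", "known", "first", "only" and "open" are said of these compounds alone.

For the measured compounds named here, in a functional assay on the whole organism with Mus musculus as the target (a higher number here means that more compound is needed for the effect, a lower number that less compound is needed), compound 2 `C=Cc1cccn1N(C)c1ccncc1` gives 8.3 mg/kg, the only exact number so far. Compound 1 `CN(c1ccncc1)n1cccc1CO` reaches only a limit, > 20 mg/kg. Compound 3 `CN(c1ccncc1)n1cccc1C#N` keeps the shared core and alters the same aromatic carbon again: cyano in place of vinyl on an aromatic carbon, with cyano in place of vinyl. Going by the values given here, one measured step bears on this carbon, vinyl in place of hydroxymethyl, which gave an at least 2.4-fold lower number from compound 1 to compound 2 (0.38 log units; beyond the scatter). From the compounds shown here alone, that step shows that the group here can shift the number, but its full size stays open since one end is a limit. It says nothing directly about cyano. In this assay, a change within the scatter is therefore expected, with a slight lean towards a higher number. The expected change is a 1.4-fold higher number from compound 2 to compound 3 (0.16 log units; within the scatter). For compound 3 the estimated dose is 12 mg/kg, with an expected range of 4 mg/kg to 25 mg/kg.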

Compound 3, dose for half-maximal effect: > 20 mg/kg
Compound 3 was reported as a limit; the forecaster's own chance of this, stated with the estimate: 30%; middle value at least 1.6-fold (0.22 log units) away from the limit.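

In this assay, for the compounds shown here, cyano in place of vinyl gives an at least 2.4-fold higher number from compound 2 to compound 3 (0.38 log units; beyond the scatter), so a second group at this aromatic carbon now needs clearly more compound than vinyl, where the earlier compounds offered only hydroxymethyl for comparison. From the compounds shown here alone, compound 3 is reported only as a limit, > 20 mg/kg, so the true size of this step stays unknown. Of the three groups shown at this carbon, only the vinyl of compound 2 gives an exact number, and the steps between hydroxymethyl and cyano cannot be read: the limit of > 20 mg/kg in this assay, at which 2 of the 3 values shown sit.

The compounds shown leave open how much dose compound 1 and compound 3 would actually need. They also leave open whether the double bond of vinyl matters, or whether an ethyl group, a longer chain or an amine at this carbon would match compound 2.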